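The source may hold more compounds than are shown below. What is called first, only, known or untested is meant among the compounds shown, and "the series" means these compounds.

Compound 1 `O=C(CCCCCCc1ccccc1)c1nncs1` gives, in an assay on HEK-293T cells for inhibition of diacylglycerol lipase-alpha (Homo sapiens), read by colorimetric assay (a lower number here means a stronger inhibitor, a higher number a weaker inhibitor), a value of > 10000 nM, which is a limit of the assay. Compound 2 `O=C(CCCCCCc1ccccc1)c1nc(C(F)(F)F)co1` gives 214 nM in this assay. Compound 3 `O=C(CCCCCCc1ccccc1)c1nc(Cl)co1` gives 2400 nM in this assay.

Among the two numbers shown, compound 3 stands highest; the value of compound 1 sits at the limit of > 10000 nM in this assay, at which 1 of the 3 values shown sits. The step of an at least 4.1-fold lower number from compound 1 to compound 3 (0.61 log units; beyond the scatter) shows the core change; the step of an 11-fold higher number from compound 2 to compound 3 (1.05 log units; beyond the scatter) shows how much the group on the ring carbon matters. Compound 4 `COc1coc(C(=O)CCCCCCc2ccccc2)n1` differs from compound 3 by methoxy in place of chloro on an aromatic carbon. Among the compounds with values here, no measured step involves methoxy, so only the large effect seen between compound 2 and compound 3 indicates that this position is sensitive. Compound 4 is therefore expected to show a 1.6-fold lower number from compound 3 to compound 4 (0.20 log units; within the scatter), giving an estimated 1500 nM with a range from 300 nM to 8000 nM.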

Compound 4, half-maximal inhibitory concentration: > 10000 nM
Compound 4 was reported as a limit (the forecaster's own chance of this, stated with the estimate: 10%); middle value at least 6.6-fold (0.82 log units) away from the limit.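

In this assay compound 4 gives > 10000 nM, which is a limit of the assay. The position next to the ring nitrogen therefore tolerates methoxy less well than either earlier group, with an at least 4.1-fold higher number from compound 3 to compound 4 (0.61 log units; beyond the scatter) and an at least 46-fold higher number from compound 2 to compound 4 (1.66 log units; beyond the scatter), so the order trifluoromethyl, chloro, methoxy now spans the full range of the assay. The step between compound 1 and compound 4 cannot be read: the limit of > 10000 nM in this assay, at which 2 of the 4 values shown sit.

From the compounds shown here alone, how far compound 4 lies past its limit stays open. Also open, going by these compounds, is whether a nitrile or an amine on this carbon would behave more like trifluoromethyl or like methoxy.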